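Coumarin-triazole isatin series: halogen swap on a five-carbon linker

The source may hold more compounds than are shown below. What is called first, only, known or untested is meant among the compounds shown, and "the series" means these compounds.

Measured so far in a functional assay on COLO 205 cells (Homo sapiens) for inhibition, read by sulforhodamine B assay, with a stated time of 48 h, tested at 50 uM; a higher number here means more inhibition of growth at the concentration tested, a lower number less inhibition of growth:

compound 1, `O=C1C(=O)N(CCCCn2cc(COc3cc(=O)oc4ccccc34)nn2)c2ccc(F)cc21`, 64%
compound 2, `O=C1C(=O)N(CCCCCn2cc(COc3cc(=O)oc4ccccc34)nn2)c2ccc(Br)cc21`, 39%
compound 3, `O=C1C(=O)N(CCCn2cc(COc3cc(=O)oc4ccccc34)nn2)c2ccc(I)cc21`, 56%

Compound 2 stands lowest of the three numbers. Its nearest neighbour is compound 3, whose value lies beyond the scatter above it, and compound 1 lies further still above it, also beyond the scatter. No two of the measured compounds differ in only one place, so no single-point step can be read from them: compound 1 and compound 2 differ in both halogen and linker length, as do compound 3 and compound 2.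

Compound 4, `O=C1C(=O)N(CCCCCn2cc(COc3cc(=O)oc4ccccc34)nn2)c2ccc(F)cc21`, is not yet measured. It differs from compound 2 by fluoro in place of bromo on an aromatic carbon, on an aromatic carbon meta to a fused ring and para to a fused ring. For the measured compounds named here, compound 1 carries the same fluoro group on a shorter linker and gives the highest number of the three, so a moderate rise is expected for this assay, though the data give no isolated halogen step to lean on. The expected step of a number 11 percentage points higher from compound 2 to compound 4 (beyond the scatter) is upward and roughly at the edge of the scatter. Compound 4 is expected to give about 50%, within 32% to 68%.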

Compound 4, percent growth inhibition at one concentration: 56%
Compound 4: middle estimate off by 6 percentage points, on the low side; measured number inside the range.
By their numbers in this assay, from the lowest: compound 2; then compounds 3, 4 and 1 (each within the scatter of the next).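

For the compounds shown here, with the linker held fixed, this assay gives the first single-place comparison: fluoro in place of bromo on an aromatic carbon, meta to a fused ring and para to a fused ring, gives a number 17 percentage points higher from compound 2 to compound 4 (beyond the scatter) and shows that the halogen at this position alone can move the growth-inhibition number beyond the scatter. Among the fluoro compounds, which differ only in linker length, compound 1 gives 64% and compound 4 gives 56%, within the scatter of each other, so this pair shows no linker effect. No measurement at hand explains the halogen step.

On these data alone, it remains open whether chloro, a methoxy group or an amine at this position would read closer to bromo or to fluoro. As far as these compounds go, it is also open whether the same halogen step holds on the shorter linkers of compound 1 and compound 3.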